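This account rests on a few compounds, and the source may have more. Where it says the series, first, only, none or still open, it means among the compounds named here.

Working notes on the series.

Three compounds carry the shared core with an enone linking to an aryl carbonyl. In a functional assay on HCC 2998 cells (Homo sapiens) for inhibition, read by sulforhodamine B assay, with a stated time of 48 h (a lower number here means a stronger inhibitor of growth, a higher number a weaker inhibitor of growth), compound 1 `COc1ccc(-c2cc(/C=C/C(=O)c3cc(OC)c(OC)c(OC)c3)[nH]n2)cc1OC` gives 3400 nM. In this assay compound 2 `COc1ccc(-c2cc(/C=C/C(=O)c3ccc(N)cc3)[nH]n2)cc1` gives 3360 nM. Compound 3 `COc1ccc(C(=O)/C=C/c2cc(-c3cc(OC)c(OC)c(OC)c3)n[nH]2)cc1` in this assay gives 3400 nM, level with compound 1 at the digits read and, together with compound 1, the highest of the three numbers; the gap from compound 3 to compound 2 sits within the scatter, so the three values are not distinguished by this assay.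

The next compound, compound 4 `COc1cc(-c2cc(/C=C/C(=O)c3ccc(F)c(F)c3)[nH]n2)cc(OC)c1OC`, has not yet been run in this assay. It differs from compound 3 by 3,4-difluorophenyl in place of 4-methoxyphenyl on a carbonyl carbon. Among the compounds with values here, no step between two measured compounds speaks to this exchange, and the three measured values give no direction for it. The step from compound 3 to compound 4 is expected to be no change at the digits printed from compound 3 to compound 4 (within the scatter), that is, none beyond the scatter. Compound 4 is therefore estimated at 3400 nM in this assay, with a range from 1500 nM to 8000 nM.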

Compound 4, concentration for total growth inhibition: 34100 nM
The estimate for compound 4 lay 10-fold (1.00 log units) below the measured number; the whole stated range lies below it.
By their numbers in this assay, from the lowest: compounds 2, 1 and 3 (each within the scatter of the next); then compound 4.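

In this assay, within the data shown here, the exchange of 4-methoxyphenyl for 3,4-difluorophenyl on a carbonyl carbon gives a 10-fold higher number from compound 3 to compound 4 (1.00 log units; beyond the scatter) and is the first step that lies beyond the scatter. The aryl group on this carbonyl carbon therefore matters for growth inhibition, with compound 4 the weaker inhibitor of the pair, something the three earlier values could not show, as they were not distinguished from one another. Nothing measured here explains the weaker inhibition.

Among these compounds, the single step removes the methoxy group and adds both fluorines at once, so it remains open whether the shift follows from the loss of the one or the arrival of the others. Also open, from the compounds shown here alone, is how an unsubstituted phenyl or a 4-fluorophenyl on this carbonyl carbon would read, as either would help to separate these two changes.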